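A few compounds are considered here, and "the series" means these few. Any claim that something is new, unique, unknown or untested is made for them only; others in the source may bear on it.

Compound 1, `O=c1nc(-c2ccccc2)c2cc(-c3ccccc3F)ccc2[nH]1`, gives 50000 nM in an ADME assay on THP-1 cells (Homo sapiens) for cytotoxicity, read by MTT assay, with a stated time of 72 h; on this read-out lower numbers stand for an effect already at smaller amounts and higher numbers for an effect only at larger amounts of compound. Compound 2, `CNC(=O)c1cccc(-c2ccc3[nH]c(=O)nc(-c4ccccc4)c3c2)c1`, reaches only a limit of this assay, > 50000 nM. Compound 3, `O=c1nc(-c2ccccc2)c2ccc(-c3ccc(F)cc3)cc2[nH]1`, likewise reaches only a limit of this assay, > 50000 nM.

Among the measured compounds shown here, compound 1 is thus the one compound of the three for which this assay returns an actual number; the other two sit at the limit of > 50000 nM in this assay, at which 2 of the 3 values shown sit. All three share the same core and differ only in the group carried on its six-membered carbon ring.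

Compound 4, `Cc1ccc2[nH]c(=O)nc(-c3ccccc3)c2c1`, has not yet been tested. It departs from compound 1 by methyl in place of 2-fluorophenyl on an aromatic carbon. For the measured compounds named here, no step between two measured compounds is available to show what this kind of change does here, so the expectation rests on the values of the three measured compounds alone, all of which lie at or past the same point. The step from compound 1 to compound 4 is therefore expected to be no change at the digits printed from compound 1 to compound 4 (within the scatter), none beyond the usual scatter, in either direction. Compound 4 is accordingly estimated to give 50000 nM, with a range from 25000 nM to 100000 nM, and a good chance that this assay returns only a limit.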

Compound 4, half-maximal effective concentration: > 50000 nM
Compound 4 ended at the assay's limit (the forecaster's own chance of this, stated with the estimate: 60%); the middle value lies on the limit itself.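

Swapping 2-fluorophenyl for methyl on this aromatic carbon takes away the whole ring, yet the value does not fall: the step reads a number no lower from compound 1 to compound 4 (the limit leaves the size open). In this assay compound 4 gives > 50000 nM, which is a limit and not a number, so the size of this step cannot be read. The ring of compound 1 is therefore not needed here for the value to stay this high, and the series still offers almost no numbers to compare: the limit of > 50000 nM in this assay, at which 3 of the 4 values shown sit.

From the compounds shown here alone, whether an amine, a carboxylic acid or a longer chain on this carbon would bring a number clearly lower in this assay stays open. Going by these compounds, it also stays open what the shared core would give with only hydrogen at this place.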